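The source may hold more compounds than are shown below. What is called first, only, known or untested is meant among the compounds shown, and "the series" means these compounds.

Compound 1 `O=C(O)CCc1ccc(NCc2ccc(Cl)cc2)cc1` is one of two measured compounds in a functional assay on CHO cells for agonist activity at Free fatty acid receptor 1 (Homo sapiens), read by reporter gene assay; on this read-out lower numbers stand for smaller maximal responses and higher numbers for larger maximal responses. In this assay compound 1 gives 111%. Among the measured compounds shown here, compound 2 `O=C(O)CCc1ccc(NCc2ccc(Cl)c(Cl)c2)cc1` is its only measured neighbour; in this assay compound 2 gives 117%. Compound 1 thus holds the lower of the two numbers, though the step to compound 2, a number 6 percentage points higher from compound 1 to compound 2 (within the scatter), does not stretch beyond the usual scatter.

Compound 3 `O=C(O)CCc1ccc(NCc2ccccc2)cc1` differs from compound 1 in a single place: hydrogen in place of chloro on an aromatic carbon. For the measured compounds named here, the one measured step that bears on this change is the addition of chloro between compound 1 and compound 2, a number 6 percentage points higher from compound 1 to compound 2 (within the scatter), which stayed within the scatter. Removing a chloro from compound 1 is the reverse kind of change, and on the basis of that single step, the account expects no step beyond the scatter for compound 3; the estimated step is a number 3 percentage points lower from compound 1 to compound 3 (within the scatter).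

The estimated largest response of compound 3 in this assay is therefore 108%, with an expected range from 92% to 124%.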

Compound 3, largest response reached (reported as percent of maximum), in percent of the reference or control that the assay uses: 144%
Compound 3: middle estimate off by 36 percentage points, on the low side, and the stated range ends below it.
By their numbers in this assay, from the lowest: compounds 1 and 2 (each within the scatter of the next); then compound 3.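

In this assay, hydrogen in place of chloro on the aromatic carbon para to a large group brings a number 33 percentage points higher from compound 1 to compound 3 (beyond the scatter) and so shows that the maximal response is sensitive to the group at this position. The earlier step of a number 6 percentage points higher from compound 1 to compound 2 (within the scatter) added a second chloro at another carbon of the ring and kept this chloro in place, so it could not show what removing this chloro would do; across these three compounds, the two chloro changes therefore do not behave alike. No measurement shown here explains the size of the new step.

The compounds shown leave open whether the larger response depends on the absence of a chloro in particular or would also appear with another group at this position, such as fluoro, methyl or methoxy. They also leave open whether the same hydrogen-for-chloro change would have a similar effect on a core with a longer chain leading to the carboxylic acid, or in the presence of the second chloro of compound 2.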